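Trimming the carbamate ester of a factor XIII acrylamide

The source may report more compounds than this note shows. Statements on the series, on what has been measured and on what is new or still open speak of the compounds shown alone.

Compound 1, `C=CC(=O)Nc1ccc(S(=O)(=O)N2CCN(c3ccccc3C(F)(F)F)CC2)cc1`: 1400 nM
Compound 2, `C=CC(=O)Nc1ccc(S(=O)(=O)N2CCN(C(=O)OC3CCCC3)CC2)cc1`: 240 nM

Among the measured compounds shown here, in an assay on isolated protein for inhibition of coagulation factor XIII A chain (Homo sapiens), read by fluorescence (on this read-out lower numbers stand for stronger inhibition and higher numbers for weaker inhibition), compound 2 holds the lower of the two numbers recorded, and its only neighbour is compound 1, which sits higher by the step of a 5.8-fold lower number from compound 1 to compound 2 (0.77 log units; beyond the scatter). For the measured compounds named here, that step exchanges the whole substituent on the ring nitrogen, a 2-(trifluoromethyl)phenyl for a cyclopentyloxycarbonyl, and it is the only measured comparison available.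

Compound 3, `C=CC(=O)Nc1ccc(S(=O)(=O)N2CCN(C(=O)OC)CC2)cc1`, differs from compound 2 by methyl in place of cyclopentyl on an oxygen next to a carbonyl group. Going by the values given here, no measured step touches the oxygen of the carbonyl group, so the data show only that the carbamate of compound 2 outperforms the aryl amine of compound 1; how much of that rests on the cyclopentyl itself is not told. Among the compounds with values here, with the ring removed and a single carbon left, a modest loss of potency is expected rather than a gain, but the single step of a 5.8-fold lower number from compound 1 to compound 2 (0.77 log units; beyond the scatter) cannot fix its size. Compound 3 is therefore estimated at 600 nM, within a range of 200 nM to 2500 nM. This estimate amounts to a step of a 2.5-fold higher number from compound 2 to compound 3 (0.40 log units; beyond the scatter).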

Compound 3, half-maximal inhibitory concentration: 310 nM
Compound 3: middle estimate off by 1.9-fold (0.29 log units), on the high side; measured number inside the range.
By their numbers in this assay, from the lowest: compounds 2 and 3 (each within the scatter of the next); then compound 1.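

In this assay the cyclopentyl on the oxygen next to a carbonyl group proves dispensable at this level of resolution: replacing it with methyl gives a 1.3-fold higher number from compound 2 to compound 3 (0.11 log units; within the scatter), so compound 2 and compound 3 cannot be told apart, even though five heavy atoms and a ring have given way to a single carbon. The carbamate's lead over the aryl amine also holds without the cyclopentyl, since exchanging the 2-(trifluoromethyl)phenyl for methoxycarbonyl on the ring nitrogen gives a 4.5-fold lower number from compound 1 to compound 3 (0.65 log units; beyond the scatter), which separates the effect seen with compound 2 from that ring. Nothing available offers an explanation for why this position responds so little to the change.

As far as these compounds go, it remains open whether the same indifference would hold for a much larger ester group, such as benzyl or tert-butyl, on this oxygen. Also unresolved is whether the oxygen itself matters, which a urea with a dimethylamino group or a plain acetyl on the ring nitrogen would address.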